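The source may hold more compounds than are shown below. What is called first, only, known or untested is meant among the compounds shown, and "the series" means these compounds.

Working notes on four chromanones. Compound 1 `COc1ccc2c(c1)OC(c1cccc([N+](=O)[O-])c1)C(c1ccccc1)C2=O`, compound 2 `COc1ccc2c(c1)OC(c1ccc([N+](=O)[O-])cc1)C(c1ccccc1)C2=O` and compound 3 `CCOc1ccc2c(c1)OC(c1cccc([N+](=O)[O-])c1)C(c1ccccc1)C2=O` have been measured in a functional assay on HL-60 cells (Homo sapiens) for cytotoxicity, read by MTT assay, with a stated time of 5 days; a lower number here means that less compound is tolerated, a higher number that more compound is tolerated; compound 4 `CCOc1ccc2c(c1)OC(c1ccc([N+](=O)[O-])cc1)C(c1ccccc1)C2=O` has not. Compound 1 reaches only the limit of the assay, > 2500000 nM, and gives no number. Compound 2 gives 73200 nM in this assay. Compound 3 likewise stops at the limit of > 2500000 nM in this assay, so no number is known for it either.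

Going by the values given here, the change from compound 1 to compound 2 is 4-nitrophenyl in place of 3-nitrophenyl on a saturated ring carbon; the step it made is an at least 34-fold lower number from compound 1 to compound 2 (1.53 log units; beyond the scatter), the only readable step in the set. The core of compound 3 differs from the core of compound 1 by methyl in place of hydrogen on a saturated chain carbon bound to an oxygen on an aromatic ring; the matching step, a step that the two limits leave unreadable from compound 1 to compound 3, cannot be sized, due to the limit of > 2500000 nM in this assay, at which 2 of the 3 values shown sit. Compound 4 arises from compound 3 by 4-nitrophenyl in place of 3-nitrophenyl on a saturated ring carbon, the same change at the same place as between compound 1 and compound 2.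

The step from compound 3 to compound 4 is expected to run as an at least 31-fold lower number from compound 3 to compound 4 (1.49 log units; beyond the scatter), resting on an at least 34-fold lower number from compound 1 to compound 2 (1.53 log units; beyond the scatter). Compound 4 is therefore estimated at 80000 nM in this assay, with an expected range of 20000 nM to 500000 nM.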

Compound 4, half-maximal cytotoxic concentration: 203000 nM
Compound 4: the middle estimate sits 2.5-fold (0.40 log units) below what was measured; the measured number falls inside the stated range.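

In this assay, 4-nitrophenyl in place of 3-nitrophenyl on a saturated ring carbon again gives a lower number on the core of compound 3, with an at least 12-fold lower number from compound 3 to compound 4 (1.09 log units; beyond the scatter). The direction of the change therefore carries over between the two cores shown, and the two steps compare as follows: the same change on two cores in this assay, an at least 34-fold lower number (1.53 log units; beyond the scatter) from compound 1 to compound 2 and an at least 12-fold lower number (1.09 log units; beyond the scatter) from compound 3 to compound 4; the limit leaves it open whether they differ. This does not show that the size carries over, and neither step has a known full size, due to the assay limit: the limit of > 2500000 nM in this assay, at which 2 of the 4 values shown sit.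

Methyl in place of hydrogen on a saturated chain carbon bound to an oxygen on an aromatic ring is readable only as a 2.8-fold higher number from compound 2 to compound 4 (0.44 log units; beyond the scatter), while the matching step between the two 3-nitrophenyl compounds cannot be read, so whether that change carries over between cores stays open. Also open, as far as these compounds go, is whether an amine or a carboxylic acid in place of the nitro group, or a longer chain on that oxygen, would follow the same course.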